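The compounds below may be only part of what the source reports. "The series", "measured", "known", "first", "only" and "open" are said of these compounds alone.

Compound 1, with the structure `CCc1ccc2nc(C(=O)Nc3c(F)cc(-c4cccc(F)c4)cc3F)c(C)c(O)c2c1`, was tested in a functional assay on A-375 cells (Homo sapiens) for antiproliferative activity, read by MTT assay, with a stated time of 24 h, tested at 33.33 ug/mL (on this read-out lower numbers stand for a weaker effect and higher numbers for a stronger effect at the one concentration tested), where it gives 28.4%. Among the two compounds with a measurement, compound 1 stands highest. Going by the values given here, the only other measured compound is compound 2, with the structure `Cc1c(C(=O)Nc2c(F)cc(-c3cccc(F)c3)cc2F)nc2ccc(OC(F)(F)F)cc2c1O`, which in this assay gives 12.3%. Among the compounds with values here, the one measured step, a number 16.1 percentage points lower from compound 1 to compound 2 (beyond the scatter), comes from putting trifluoromethoxy in place of ethyl on an aromatic carbon.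

Compound 3 has the structure `CCc1ccc2nc(C(=O)Nc3c(F)cc(-c4cccc(F)c4)cc3F)c(C)c(C(=O)O)c2c1` and has not yet been measured. It differs from compound 1 as follows: carboxy in place of hydroxy on an aromatic carbon. The measured step between compound 1 and compound 2 changes a different part of the core and therefore says nothing directly about swapping a hydroxy for a carboxy at this place. Within the data shown here, no measured step bears on the change from compound 1 to compound 3, so the expectation rests on the value of compound 1 alone, with a wide range to allow for either direction. The step expected from this change is a number 6.4 percentage points lower from compound 1 to compound 3 (within the scatter). Compound 3 is therefore estimated to give about 22%, within a range from 0% to 45%.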

Compound 3, a percentage reported as inhibition, at one concentration (the size of the read-out at that concentration, not a potency): 47.1%
For compound 3 the middle estimate is 25.1 percentage points below the measured one, and the stated range ends below it.
By their numbers in this assay, from the lowest: compound 2; then compound 1; then compound 3.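

In this assay, the place opposite the ring nitrogen proves sensitive to what it carries: carboxy in place of hydroxy gives a number 18.7 percentage points higher from compound 1 to compound 3 (beyond the scatter). Going by these compounds alone, the earlier step changed a different part of the shared core, so this is the first measured sign that the hydroxy can be given up here without a loss at the one concentration tested, and that a group of three heavy atoms in place of one, ortho to a methyl group, is compatible with a stronger effect. Nothing available explains why this change goes with the higher number.

As far as these compounds go, it remains open which feature of the carboxy matters, and a methyl ester, a primary amide or an amine at the same place would help to separate the possibilities, while a longer acid chain such as carboxymethyl would show whether the group must sit directly on the aromatic carbon. Also open, from the compounds shown here alone, is whether the step carries over to the core of compound 2, with trifluoromethoxy in place of ethyl, and whether it would hold as a difference in potency rather than at one concentration.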